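Ring Expansion on the Amide of Compound 1

The source may report more compounds than this note shows. Statements on the series, on what has been measured and on what is new or still open speak of the compounds shown alone.

Compound 1 `COc1ncc(-c2ccc3nc(NC(=O)NCC(=O)N4CCCC4)nn3c2)cc1NS(=O)(=O)c1ccc(F)cc1` stands at the weaker end of two measured compounds: in a functional assay on A549 cells (Homo sapiens) for cytotoxicity, read by MTT assay, with a stated time of 72 h (a higher number here means a weaker inhibitor, a lower number a stronger inhibitor), compound 1 gives 2190 nM, while compound 2 `CCN(CC)CCNC(=O)Nc1nc2ccc(-c3cnc(OC)c(NS(=O)(=O)c4ccc(F)cc4F)c3)cn2n1` gives 980 nM, a gap beyond the scatter. Compound 3 `COc1ncc(-c2ccc3nc(NC(=O)NCC(=O)N4CCCCC4)nn3c2)cc1NS(=O)(=O)c1ccc(F)cc1` keeps the whole of compound 1 except for one change, (piperidin-1-yl in place of pyrrolidin-1-yl on a carbonyl carbon). Among the measured compounds shown here, no measured pair shows what this change does on this core. The step is expected to be small and not beyond the scatter, in either direction, a 1.1-fold lower number from compound 1 to compound 3 (0.04 log units; within the scatter). Compound 3 is therefore expected to give about 2000 nM, within a range from 800 nM to 5000 nM.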

Compound 3, half-maximal inhibitory concentration: 2060 nM
Compound 3: the middle estimate sits 1.0-fold (0.01 log units) below what was measured; low and high end bracket the measured number.
By their numbers in this assay, from the lowest: compound 2; then compounds 3 and 1 (each within the scatter of the next).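

In this assay, piperidin-1-yl in place of pyrrolidin-1-yl on a carbonyl carbon gives a 1.1-fold lower number from compound 1 to compound 3 (0.03 log units; within the scatter). Among the compounds shown here, this is the first pair differing in one place, and it shows that on this core the six-membered ring and the five-membered ring cannot be told apart at this position. Nothing measured on either group bears on this result. The compounds shown leave open whether a morpholine ring or an open-chain diethylamino group in this place would shift the number beyond the scatter.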